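The source may hold more compounds than are shown below. What is called first, only, known or untested is meant among the compounds shown, and "the series" means these compounds.

Compound 1, `CCCCCCCCC#Cc1cn(C/C=C\CN2C(=O)c3ccccc3C2=O)c(=O)[nH]c1=O`, gives 68000 nM in a functional assay on MIA PaCa-2 cells (Homo sapiens) for antiproliferative activity, read by MTT assay, with a stated time of 3 days; a higher number here means a weaker inhibitor, a lower number a stronger inhibitor. Compound 3, `CCCCCC#Cc1cn(C/C=C/CN2C(=O)c3ccccc3C2=O)c(=O)[nH]c1=O`, gives 60000 nM in this assay. Compound 2, `CCCCCCCCC#Cc1cn(C/C=C/CN2C(=O)c3ccccc3C2=O)c(=O)[nH]c1=O`, reaches only the limit of the assay at > 100000 nM.

In this assay compound 1 stands with compound 3, the two values within the usual scatter of each other, while compound 2 gives a limit rather than a number. The steps among these three are small: an at least 1.4-fold higher number from compound 1 to compound 2 (0.16 log units; that floor lies within the scatter), and an at least 1.6-fold lower number from compound 2 to compound 3 (0.22 log units; that floor lies within the scatter), both at floors within the scatter.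

Compound 4, `O=C1c2ccccc2C(=O)N1C/C=C\Cn1cc(C#CCCc2ccccc2)c(=O)[nH]c1=O`, is not yet measured. It differs from compound 1 by phenyl in place of hexyl on a saturated chain carbon, two bonds along the chain from a triple-bonded carbon. Going by the values given here, no measured step swaps an alkyl chain for an aromatic ring; the closest is the shortening of the same chain from compound 2 to compound 3, which did not move the number beyond the scatter. Compound 4 is therefore expected to lie close to compound 1, with an estimated step of a 1.1-fold lower number from compound 1 to compound 4 (0.05 log units; within the scatter). Compound 4 is expected to give about 60000 nM, in a range from 20000 nM to 150000 nM.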

Compound 4, half-maximal inhibitory concentration: > 100000 nM
Compound 4 gave a limit, no number; the forecaster's own chance of this, stated with the estimate: 30%; middle value at least 1.6-fold (0.22 log units) from the limit.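

Phenyl in place of hexyl, on a saturated chain carbon, two bonds along the chain from a triple-bonded carbon, is the first change shown that puts an aromatic ring on this chain, and it gives an at least 1.4-fold higher number from compound 1 to compound 4 (0.16 log units; that floor lies within the scatter). Compound 4 gives > 100000 nM, which is a limit and not a number. The step is therefore only a floor within the scatter: it shows no gain from phenyl in this assay, while its true size cannot be read, and the values shown leave little room to separate these compounds: the limit of > 100000 nM in this assay, at which 2 of the 4 values shown sit.

As far as these compounds go, whether an amine or a carboxylic acid at the end of this chain would give a value clear of the limit stays open. So does whether phenyl would behave alike with the double bond drawn E rather than Z.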